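Bromo on compound 3: expected change in growth inhibition

The source may report more compounds than this note shows. Statements on the series, on what has been measured and on what is new or still open speak of the compounds shown alone.

Measured so far in a functional assay on HT-29 cells (Homo sapiens) for cytotoxicity, read by sulforhodamine B assay, with a stated time of 72 h (a lower number here means a stronger inhibitor of growth, a higher number a weaker inhibitor of growth), for the series:
- compound 1 `COn1cc(C2CC(=O)N=C(N)N2)c2ccccc21` gives "not active" (no number reported)
- compound 2 `Cn1cc(C2CCN=C(N)N2)c2cc(Br)ccc21` gives 13700 nM
- compound 3 `CC(=O)/N=C1\NCCC(c2cn(C)c3ccccc23)N1` gives 7400 nM

Compound 2 at 13700 nM and compound 3 at 7400 nM lie within the scatter of each other, and compound 1 gives no number. Compound 4 `CC(=O)/N=C1\NCCC(c2cn(C)c3ccc(Br)cc23)N1` comes from compound 3 by bromo in place of hydrogen on an aromatic carbon on the shared core, with bromo in place of hydrogen on an aromatic carbon. Among the compounds with values here, no measured pair isolates this change, so the expectation is loose. The expected step is an 8.2-fold lower number from compound 3 to compound 4 (0.91 log units; beyond the scatter) in this assay toward stronger growth inhibition, beyond the scatter. The estimate for compound 4 is 900 nM with an expected range from 250 nM to 3500 nM for now.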

Compound 4, concentration for 50% growth inhibition: 310 nM
Estimate against measurement, compound 4: 2.9-fold (0.46 log units) above; low and high end bracket the measured number.
By their numbers in this assay, from the lowest: compound 4; then compounds 3 and 2 (each within the scatter of the next).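

In this assay, within the data shown here, bromo in place of hydrogen on an aromatic carbon gives a 24-fold lower number from compound 3 to compound 4 (1.38 log units; beyond the scatter) and is the only step that isolates one change. This carbon, meta to a fused ring and para to a fused ring, accepts bromo with a large gain in growth inhibition. Nothing available bears on the reason for this step. As far as these compounds go, whether chloro, methoxy or an amine at this carbon gives a step of similar size stays open. Also open, from the compounds shown here alone, is whether bromo on another aromatic carbon of this ring does the same.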